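From 4-ethylphenyl to thiophen-3-yl: a step awaiting measurement

This account rests on a few compounds, and the source may have more. Where it says the series, first, only, none or still open, it means among the compounds named here.

Compound 1 `CCc1ccc(-c2nc3ccccn3c2Sc2ccccc2)cc1`: 61700 nM
Compound 2 `CS(=O)(=O)c1ccc(-c2nc3ccccn3c2Sc2cccc3ccccc23)cc1`: 56200 nM
Compound 3 `Cc1ccc2nc(-c3ccc(Cl)cc3)c(Sc3ccccc3)n2c1`: > 100000 nM

These three compounds were tested in a functional assay on U-87MG ATCC cells for inhibition, with U-87 MG (Homo sapiens) as the target, read by MTT assay, with a stated time of 48 h; a lower number here means a stronger inhibitor, a higher number a weaker inhibitor. Compound 1 at 61700 nM and compound 2 at 56200 nM lie within the usual scatter of each other, so these two cannot be told apart. Compound 3 gives only a limit, > 100000 nM, and not a number.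

The next compound to be tested is compound 4 `c1ccc(Sc2c(-c3ccsc3)nc3ccccn23)cc1`. It keeps the core of compound 1 and its phenylsulfanyl group, while thiophen-3-yl takes the place of 4-ethylphenyl on an aromatic carbon (thiophen-3-yl in place of 4-ethylphenyl on an aromatic carbon). The new group is one five-membered aromatic ring with 1 hetero atom, where the old group had a six-membered aromatic ring of carbon only.

Among the compounds with values here, no two tested compounds differ in just one place, so the data offer no direct guide to this swap. In this assay, no step beyond the scatter is expected, though any drift is expected towards a higher number, meaning a weaker inhibitor. This expectation rests on compound 1 at 61700 nM, which already sits close to the limit of > 100000 nM in this assay, at which 1 of the 3 values shown sits. The estimated step is a 1.2-fold higher number from compound 1 to compound 4 (0.08 log units; within the scatter). For compound 4 the estimated value is 75000 nM, with an expected range from 35000 nM to 100000 nM.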

Compound 4, half-maximal inhibitory concentration: 58600 nM
The estimate for compound 4 lay 1.3-fold (0.11 log units) above the measured number; measured number inside the range.
By their numbers in this assay, from the lowest: compounds 2, 4 and 1 (each within the scatter of the next). At a limit, above all of these: compound 3.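

Within the data shown here, the change from 4-ethylphenyl to thiophen-3-yl gives the first direct comparison at this position, and in this assay it is a 1.1-fold lower number from compound 1 to compound 4 (0.02 log units; within the scatter). Compound 1 and compound 4 therefore cannot be told apart, even though the five-membered ring with a sulfur atom and one hydrogen-bond acceptor replaces a six-membered ring of carbon only that carries an ethyl chain and has no acceptor. The result says little about any weakening at this position, because compound 3 gives only a limit and not a number, so the upper end of the assay lies close: the limit of > 100000 nM in this assay, at which 1 of the 4 values shown sits.

Compound 2 and compound 3 each differ from compound 1 in more than one place, so their differences from it cannot be read as steps. Going by these compounds, it stays open whether an amine, a carboxylic acid or a longer chain on this aromatic carbon would move the number beyond the scatter, and whether any group here could give a clearly stronger inhibitor.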